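Methoxy to hydroxy on the aryl of compound 3

The source may report more compounds than this note shows. Statements on the series, on what has been measured and on what is new or still open speak of the compounds shown alone.

Three ureas on a shared core have been run in a functional assay on NCI-H322M cells (Homo sapiens) for inhibition, read by sulforhodamine B assay, with a stated time of 48 h; on this read-out lower numbers stand for stronger inhibition of growth and higher numbers for weaker inhibition of growth. Compound 1 `O=C(Nc1cccc(-n2cc(-c3ccncc3)c(-c3ccc(Cl)c(O)c3)n2)c1)Nc1cccc(C(F)(F)F)c1` gives 6410 nM. Compound 2 `O=C(Nc1cccc(-n2cc(-c3ccncc3)c(-c3ccc(Cl)c(O)c3)n2)c1)Nc1ccc(Cl)c(Cl)c1` gives 2890 nM; the replacement of 3-(trifluoromethyl)phenyl by 3,4-dichlorophenyl on the amide-type nitrogen reads a 2.2-fold lower number from compound 1 to compound 2 (0.35 log units; beyond the scatter). Compound 3 `COc1cc(-c2nn(-c3cccc(NC(=O)Nc4ccc(Cl)c(C(F)(F)F)c4)c3)cc2-c2ccncc2)ccc1Cl` gives 1500 nM. Of the three numbers, that of compound 3 sits at the low end, with its gap to compound 2 within the scatter and its gap to compound 1 beyond it.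

Compound 4 `O=C(Nc1cccc(-n2cc(-c3ccncc3)c(-c3ccc(Cl)c(O)c3)n2)c1)Nc1ccc(Cl)c(C(F)(F)F)c1` is compound 3 with hydrogen in place of methyl on an oxygen on an aromatic ring. Among the measured compounds shown here, no measured step touches this oxygen. For the measured compounds named here, compounds 1 and 2 both carry the hydroxy group, yet each also differs from compound 3 in the aryl on the urea, so the pair of compound 2 and compound 3 combines two changes and shows only two values within the scatter of each other. Going by the values given here, the single step in hand, a 2.2-fold lower number from compound 1 to compound 2 (0.35 log units; beyond the scatter), concerns the other end of the molecule and does not bear on the present change. Among the compounds with values here, with no direct precedent, the expected step from compound 3 to compound 4 in this assay is a 1.3-fold higher number from compound 3 to compound 4 (0.12 log units; within the scatter), not beyond the scatter in either direction. Compound 4 is therefore estimated at 2000 nM, with a range from 700 nM to 6000 nM.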

Compound 4, concentration for 50% growth inhibition: 1090 nM
The estimate for compound 4 lay 1.8-fold (0.26 log units) above the measured number; low and high end bracket the measured number.
By their numbers in this assay, from the lowest: compounds 4, 3 and 2 (each within the scatter of the next, the first and the last beyond it); then compound 1.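

In this assay, among the compounds shown here, the first direct reading at this oxygen gives a 1.4-fold lower number from compound 3 to compound 4 (0.14 log units; within the scatter), so methoxy and hydroxy cannot be told apart here, at least with the aryl on the urea that compounds 3 and 4 share. With the hydroxy held constant, the urea aryl gives steps beyond the scatter: trifluoromethyl in place of chloro gives a 2.7-fold lower number from compound 2 to compound 4 (0.42 log units; beyond the scatter), and chloro in place of hydrogen gives a 5.9-fold lower number from compound 1 to compound 4 (0.77 log units; beyond the scatter), so among the hydroxy compounds shown, these differences at the urea end register in this read-out while the methyl-to-hydrogen change on the oxygen does not. No measurement shown accounts for any of these steps.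

From the compounds shown here alone, the reading at the oxygen rests on a single pair, so it remains open whether methoxy and hydroxy would also stay within the scatter of each other with the urea aryl of compound 1 or compound 2. Also open, going by these compounds, is how this assay would respond to a longer chain on this oxygen, such as ethoxy or a 2-aminoethoxy group, or to an amine in place of the hydroxy.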